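The source may hold more compounds than are shown below. What is called first, only, known or untested is meant among the compounds shown, and "the series" means these compounds.

Measured compounds: Compound 1 `CC(C)(C)c1ccc(NC(=O)NCCCCl)cc1` gives 49000 nM in a functional assay on MCF7 cells (Homo sapiens) for antiproliferative activity, with a stated time of 48 h; a higher number here means a weaker inhibitor, a lower number a stronger inhibitor. Compound 2 `CCCCC(O)c1cccc(NC(=O)NC(=O)CC)c1` reaches only the limit > 100000 nM in this assay. Compound 3 `CCCCC(OC)c1cccc(NC(=O)NC(=O)CC)c1` likewise reaches only the limit > 100000 nM in this assay.

Compound 3 thus stands at the limit where two of the three values sit (the limit of > 100000 nM in this assay, at which 2 of the 3 values shown sit); its own number is not known. Within the data shown here, the single step between measured compounds, a step that the two limits leave unreadable from compound 2 to compound 3, is itself unreadable from the two limits, so the set gives no measured step of known size. Compound 4 `CCCCC(OC)c1cccc(NC(=O)CCCl)c1` differs from compound 3 by 2-chloroethyl in place of propanoylamino on a carbonyl carbon. Among the measured compounds shown here, no measured step covers this change. For the measured compounds named here, compound 1, the only compound with a readable number, gives 49000 nM, while compound 2 and compound 3, which share the propanoylamino group that leaves here, do not give a readable number. On that footing compound 4 is expected to give a readable number, the step of an at least 1.6-fold lower number from compound 3 to compound 4 (0.22 log units; that floor lies within the scatter) being an estimate rather than a reading. Compound 4 is therefore estimated at 60000 nM, in the range 15000 nM to 100000 nM, with a real chance that only a limit is returned.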

Compound 4, half-maximal inhibitory concentration: > 100000 nM
Compound 4: no number, only a limit; the forecaster's own chance of this, stated with the estimate: 40%; middle value at least 1.6-fold (0.22 log units) from the limit.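

Compound 3 and compound 4 each return only a limit in this assay, so the step between them cannot be read: the limit of > 100000 nM in this assay, at which 3 of the 4 values shown sit.

The compounds shown leave open what numbers compound 3 and compound 4 would give, and whether 2-chloroethyl in place of propanoylamino on a carbonyl carbon changes the read-out at all.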